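Phenyl to Methyl on Two Related Fused Cores

A few compounds are considered here, and "the series" means these few. Any claim that something is new, unique, unknown or untested is made for them only; others in the source may bear on it.

Of the compounds shown here, three have so far been measured in an assay on isolated protein for inhibition of serine/threonine-protein kinase D2 (Homo sapiens), read by mobility shift assay, tested at 30 uM; a higher number here means more inhibition at the concentration tested (going by the name of the read-out), a lower number less inhibition. Compound 1 `Cc1cc2c(c(N)nn2C)c(=O)[nH]1` gives 5% in this assay. Compound 2 `Cn1nc(N)c2c(=O)[nH]c(-c3ccccc3)cc21` carries a phenyl where compound 1 carries a methyl. In this assay compound 2 gives 14%. Compound 3 `Cc1cc2nc(-c3ccccc3)nc(N)c2c(=O)[nH]1`, built on a different core, gives 5% in this assay; the difference between the two cores is not broken down here. Compound 3 is level with compound 1 at the digits shown, and both sit within the scatter of compound 2.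

The change from compound 2 to compound 1 is methyl in place of phenyl on an aromatic carbon, and it made a step of a number 9 percentage points lower from compound 2 to compound 1 (within the scatter). Compound 4 `Cc1nc(N)c2c(=O)[nH]c(C)cc2n1` has not yet been measured; it stands to compound 3 as compound 1 stands to compound 2, through (methyl in place of phenyl on an aromatic carbon). The two changes are the same kind of change rather than the same: in compound 1 the methyl sits on a six-membered aromatic ring with 1 nitrogen, next to the ring nitrogen and meta to a group of 1 heavy atom, whereas in compound 4 it sits on a ring with 2 nitrogen, between two ring nitrogen atoms and meta to an amino group.

Because the earlier step of a number 9 percentage points lower from compound 2 to compound 1 (within the scatter) lay within the scatter, the expected step is no change at the digits printed from compound 3 to compound 4 (within the scatter). Compound 4 is estimated to give 5% in this assay, most likely between 0% and 15%.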

Compound 4, a percentage reported as inhibition, at one concentration (the size of the read-out at that concentration, not a potency): 6%
Beside the measured number, compound 4's estimate is 1 percentage points below it; the range from low to high includes it.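

On the second core, methyl in place of phenyl on an aromatic carbon made a step of a number 1 percentage points higher from compound 3 to compound 4 (within the scatter) in this assay, so here too the change left no mark that stands clear of the scatter. Set beside the same kind of change on the first core, the new step does not differ from the earlier one: the same change on two cores in this assay, a number 9 percentage points lower (within the scatter) from compound 2 to compound 1 and a number 1 percentage points higher (within the scatter) from compound 3 to compound 4, 10 percentage points apart, within the scatter of two such steps. This shows that the two cores gave no detectable disagreement over this change, but it does not show that an effect carries from one core to the other, since neither step is beyond the scatter and there is no clear effect to carry; a single pair on each core, read at one concentration, also says nothing about potency.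

The compounds shown carry only phenyl or methyl at this aromatic carbon, so it remains open whether an amine, a carboxylic acid or a longer chain there would give a step beyond the scatter on either core. As far as these compounds go, it also remains open whether any such step, once seen on one core, would recur on the other.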